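Ester in place of octyl chain: expected cytotoxicity

The source may report more compounds than this note shows. Statements on the series, on what has been measured and on what is new or still open speak of the compounds shown alone.

Measured so far:
compound 1, `CCCCCCCc1cn(C(c2ccccc2)c2cc3cc(Br)ccc3nc2OC)nn1`, 16.6%;
compound 2, `CCCCCCCCc1cn(C(c2ccccc2)c2cc3cc(Br)ccc3nc2OC)nn1`, 12.1%.

In an ADME assay on PANC-1 cells (Homo sapiens) for cytotoxicity, read by sulforhodamine B assay, with a stated time of 48 h, tested at 10 uM (on this read-out lower numbers stand for less inhibition and higher numbers for more inhibition at the one concentration tested (going by the name of the read-out)), compound 2 holds the lower of the two numbers, with compound 1 nearest; the step of a number 4.5 percentage points lower from compound 1 to compound 2 (within the scatter) lies within the scatter. Compound 3, `CCOC(=O)c1cn(C(c2ccccc2)c2cc3cc(Br)ccc3nc2OC)nn1`, differs from compound 2 by ethoxycarbonyl in place of octyl on an aromatic carbon. For the measured compounds named here, the one measured step concerns only a longer chain and does not bear on replacing the chain with an ester, so no direction can be read from it. A change of a number 0.9 percentage points higher from compound 2 to compound 3 (within the scatter) is expected, nothing beyond the scatter. Compound 3 is therefore estimated at 13%, within 0% to 32%.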

Compound 3, a percentage reported as inhibition, at one concentration (the size of the read-out at that concentration, not a potency): 15.4%
The estimate for compound 3 lay 2.4 percentage points below the measured number; measured number inside the range.
By their numbers in this assay, from the lowest: compounds 2, 3 and 1 (each within the scatter of the next).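

In this assay, ethoxycarbonyl in place of octyl gives a number 3.3 percentage points higher from compound 2 to compound 3 (within the scatter), and ethoxycarbonyl in place of heptyl gives a number 1.2 percentage points lower from compound 1 to compound 3 (within the scatter). On this aromatic carbon, then, a plain carbon chain can give way to a shorter group carrying a carbonyl and two hydrogen-bond acceptors with no shift beyond the scatter, which the step between the two chains could not show. Nothing available explains this result. From the compounds shown here alone, whether an amine or a carboxylic acid at this position would move the number beyond the scatter remains open.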